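Swapping the benzyl substituent on a diaminoquinoxaline core

The compounds below may be only part of what the source reports. "The series", "measured", "known", "first", "only" and "open" are said of these compounds alone.

Compound 1, `Nc1cc(N)c2nc(-c3ccccc3)c(NCc3ccc(Cl)c(Cl)c3)nc2c1`, was tested in a functional assay on SK-MEL-28 cells (Homo sapiens) for inhibition, read by sulforhodamine B assay, with a stated time of 48 h (a higher number here means a weaker inhibitor of growth, a lower number a stronger inhibitor of growth), where compound 1 gives 41700 nM. Its companion compound 2, `Nc1cc(N)c2nc(-c3ccccc3)c(Sc3ccc(Cl)c(Cl)c3)nc2c1`, gives 57500 nM in this assay. Compound 1 has the lower of these two numbers, but the gap to compound 2 lies within the usual scatter, so the two are not distinguished by these data. The unmeasured compound 3, `COc1ccc(CNc2nc3cc(N)cc(N)c3nc2-c2ccccc2)cc1`, shares the core of compound 1 and differs in one place: 4-methoxyphenyl in place of 3,4-dichlorophenyl on a saturated chain carbon bound to a nitrogen on an aromatic ring. Among the compounds with values here, no measured pair shows the effect of this particular change, so there is no direct guide to its size or direction. Compound 3 is therefore expected to sit close to compound 1, with the step of a 1.3-fold higher number from compound 1 to compound 3 (0.12 log units; within the scatter) expected to be small and not clearly beyond the scatter. Compound 3 is estimated at 55000 nM, within a range from 18000 nM to 160000 nM in this assay.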

Compound 3, concentration for total growth inhibition: 32400 nM
For compound 3 the middle estimate is 1.7-fold (0.23 log units) above the measured one; low and high end bracket the measured number.
By their numbers in this assay, from the lowest: compounds 3, 1 and 2 (each within the scatter of the next).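

At the position on a saturated chain carbon bound to a nitrogen on an aromatic ring, placing 4-methoxyphenyl where 3,4-dichlorophenyl stood gives a 1.3-fold lower number from compound 1 to compound 3 (0.11 log units; within the scatter) in this assay. Within the data shown here, this is the first measured pair that differs only at this position, which the comparison of compound 1 with compound 2 could not address. The entering and leaving groups differ in their atoms, with one oxygen-bearing methoxy group in place of two chlorines, yet these data do not tell compound 1 and compound 3 apart. Still open, on these data alone, is whether an amine or a carboxylic acid on this ring would give a number clearly beyond the scatter in this assay. A longer chain in place of the saturated chain carbon is equally untested in the compounds shown. Nothing measured here offers an explanation for this result.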